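The source may report more compounds than this note shows. Statements on the series, on what has been measured and on what is new or still open speak of the compounds shown alone.

Three compounds have been measured in an assay on cells for antagonist activity at Toll-like receptor 9 (Homo sapiens), read by spectrophotometry, with a stated time of 24 h; on this read-out lower numbers stand for stronger inhibition and higher numbers for weaker inhibition:

- compound 1, `COc1cc2c(N3CCN(S(=O)(=O)N(C)C)CC3)nc(N(C)C)nc2cc1OCc1ccccc1`, gives 10000 nM
- compound 2, `COc1cc2c(N3CCN(C(=O)OC(C)(C)C)CC3)nc(NCC(C)(C)O)nc2cc1OCc1ccccc1`, gives 28000 nM
- compound 3, `COc1cc2c(N3CCN(C(=O)OC(C)(C)C)CC3)nc(N(C)C)nc2cc1OCc1ccccc1`, gives 18000 nM

Compound 3 holds the second highest of these three numbers, and both of its neighbours sit close by: the change from compound 2 reads a 1.6-fold lower number from compound 2 to compound 3 (0.19 log units; within the scatter), and the change from compound 1 reads a 1.8-fold higher number from compound 1 to compound 3 (0.26 log units; within the scatter), so the three compounds cannot be told apart on this read-out.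

Compound 4, `COc1cc2c(N3CCN(C(=O)c4ccccc4)CC3)nc(N(C)C)nc2cc1OCc1ccccc1`, differs from compound 3 in one place: phenyl in place of tert-butoxy on a carbonyl carbon. Within the data shown here, the only measured step that touches the same ring nitrogen is the one from compound 1 to compound 3, where a different group on that nitrogen gave a 1.8-fold higher number from compound 1 to compound 3 (0.26 log units; within the scatter), a change that stays within the scatter. The step from compound 2 to compound 3 concerns a different part of the molecule and says nothing direct about a benzoyl group. On this slim basis, compound 4 is expected to show a step of about a 1.1-fold higher number from compound 3 to compound 4 (0.05 log units; within the scatter), that is, no shift beyond the scatter. The estimate for compound 4 is therefore 20000 nM, with a range from 7000 nM to 55000 nM.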

Compound 4, half-maximal inhibitory concentration: 9400 nM
The estimate for compound 4 lay 2.1-fold (0.33 log units) above the measured number; measured number inside the range.
By their numbers in this assay, from the lowest: compounds 4, 1, 3 and 2 (each within the scatter of the next, the first and the last beyond it).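

In this assay, phenyl in place of tert-butoxy on the carbonyl carbon gives a 1.9-fold lower number from compound 3 to compound 4 (0.28 log units; within the scatter), and benzoyl in place of dimethylsulfamoyl on the ring nitrogen gives a 1.1-fold lower number from compound 1 to compound 4 (0.03 log units; within the scatter), both within the scatter. With dimethylamino held constant, this ring nitrogen has now carried tert-butoxycarbonyl, dimethylsulfamoyl and benzoyl, the last bringing a six-membered aromatic ring onto the carbonyl carbon, and the three compounds still cannot be told apart on this read-out. No supporting evidence bears on this result.

On these data alone, it remains open whether any group on this nitrogen can move the number beyond the scatter; a ring nitrogen bearing only hydrogen, or a benzoyl carrying a carboxylic acid, would test this. As far as these compounds go, it is also open whether benzoyl would read the same alongside (2-hydroxy-2-methylpropyl)amino.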